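Compound 1 gains a 4-butylpiperazin-1-yl group

A few compounds are considered here, and "the series" means these few. Any claim that something is new, unique, unknown or untested is made for them only; others in the source may bear on it.

In a toxicity assay on L02 cells (Homo sapiens) for cytotoxicity, read by MTT assay, with a stated time of 72 h (on this read-out lower numbers stand for stronger inhibition and higher numbers for weaker inhibition), compound 1 `CN(C)CCCCCn1c2c(c3ccccc31)C(=O)c1c[n+]([O-])c3ccccc3c1C2=O` gives 240 nM. Compound 3 `CC1(C)OCC(Cn2cc(Cn3c4c(c5ccccc53)C(=O)c3c[n+]([O-])c5ccccc5c3C4=O)nn2)O1` gives 120 nM, and these two values lie within the usual scatter of each other. Compound 2 `O=C1c2c[n+]([O-])c3ccccc3c2C(=O)c2c1c1ccccc1n2Cc1cn([C@@H]2C[C@H](O)[C@@H](CO)O2)nn1` gives 630 nM, a number higher than that of compound 1 by more than the scatter.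

Compound 4 `CCCCN1CCN(CCCCn2c3c(c4ccccc42)C(=O)c2c[n+]([O-])c4ccccc4c2C3=O)CC1` has not yet been measured. It shares its core with compound 1 and differs in one side chain, where the change reads (4-butylpiperazin-1-yl in place of (dimethylamino)methyl on a saturated chain carbon, four bonds along the chain from an aromatic nitrogen). The entering group carries a ring, which the leaving group does not.

Going by the values given here, only one measured step is available as a guide: a 5.3-fold lower number from compound 2 to compound 3 (0.72 log units; beyond the scatter). It exchanges different groups, (2,2-dimethyl-1,3-dioxolan-4-yl)methyl in place of 4-hydroxy-5-(hydroxymethyl)oxolan-2-yl on an aromatic nitrogen, so it bears on the new change only indirectly. It shows that a change of group away from the core can move the number beyond the scatter in this small set. Among the compounds with values here, no measured pair tests the change made in compound 4, and the data give no direction for it.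

In this assay, no step beyond the scatter is therefore expected, and the estimated 1.2-fold lower number from compound 1 to compound 4 (0.08 log units; within the scatter) is small. Compound 4 is estimated at 200 nM, with an expected range of 70 nM to 600 nM.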

Compound 4, half-maximal inhibitory concentration: 5690 nM
Estimate against measurement, compound 4: 28-fold (1.45 log units) below; the whole stated range lies below it.
By their numbers in this assay, from the lowest: compounds 3 and 1 (each within the scatter of the next); then compound 2; then compound 4.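

In this assay the change to 4-butylpiperazin-1-yl in place of (dimethylamino)methyl, on a saturated chain carbon, four bonds along the chain from an aromatic nitrogen, gives a 24-fold higher number from compound 1 to compound 4 (1.37 log units; beyond the scatter) and is a large step. The earlier compounds shown here left this position untested, and this step shows that the far end of the side chain is not a silent place: swapping one group there can move the number well beyond the scatter, here upward, which on this read-out means weaker inhibition of the L02 cells. No measurement at hand gives a reason for this step.

The entering group differs from the leaving one in several ways at once, since it brings a six-membered ring, a second nitrogen and a butyl group, so these compounds do not tell which of these features goes with the higher number. A piperidin-1-yl, a morpholin-4-yl or a 4-methylpiperazin-1-yl group at the same place would help to separate the effect of the ring from that of the butyl group.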